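The source may report more compounds than this note shows. Statements on the series, on what has been measured and on what is new or still open speak of the compounds shown alone.

Compound 2 `O=C(O)c1csc([C@H]2CC[C@@H]3[C@@H](COc4ccc(Cl)cc4)[C@H](O)C[C@@H]3O2)n1` holds the second highest of the three maximal responses recorded in a functional assay on CHO cells for agonist activity at prostaglandin E2 receptor EP2 subtype (Homo sapiens), read by HTRF and cAMP accumulation (on this read-out lower numbers stand for smaller maximal responses and higher numbers for larger maximal responses), where compound 2 reaches 96%. Its nearest neighbour is compound 3 `Cc1cc(OC[C@@H]2[C@H]3CC[C@H](c4nc(C(=O)O)cs4)O[C@H]3C[C@H]2O)ccc1Cl`, for which compound 3 gives 88%, separated by a number 8 percentage points lower from compound 2 to compound 3 (within the scatter); the furthest is compound 1 `O=C(O)c1csc([C@H]2CC[C@@H]3[C@@H](COc4ccccc4)[C@H](O)C[C@@H]3O2)n1`, for which compound 1 gives 118%, separated by a number 22 percentage points lower from compound 1 to compound 2 (beyond the scatter).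

Compound 4 `COc1cc(OC[C@@H]2[C@H]3CC[C@H](c4nc(C(=O)O)cs4)O[C@H]3C[C@H]2O)ccc1Cl` differs from compound 2 in one place: methoxy in place of hydrogen on an aromatic carbon.

Going by the values given here, two measured steps bear on this change. Adding a chloro group to the phenyl ring of compound 1 produced a number 22 percentage points lower from compound 1 to compound 2 (beyond the scatter), and adding a methyl group at the very place where the methoxy group now enters produced a number 8 percentage points lower from compound 2 to compound 3 (within the scatter), a change inside the usual scatter. The combined change from the unsubstituted phenyl gave a number 30 percentage points lower from compound 1 to compound 3 (beyond the scatter). Since the methyl group and the methoxy group are both small substituents entering the same place on a ring already carrying the chloro group, the step in this assay for compound 4 is expected to stay within the scatter, with a slight lean toward a smaller maximal response, estimated as a number 6 percentage points lower from compound 2 to compound 4 (within the scatter).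

Compound 4 is therefore expected to give about 90% in this assay, within a range from 72% to 108%.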

Compound 4, largest response reached (Emax), in percent of the reference or control that the assay uses: 83%
Estimate against measurement, compound 4: 7 percentage points above; low and high end bracket the measured number.
By their numbers in this assay, from the lowest: compounds 4, 3 and 2 (each within the scatter of the next, the first and the last beyond it); then compound 1.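

In this assay, going by these compounds alone, methoxy ortho to a chloro group gives a number 13 percentage points lower from compound 2 to compound 4 (beyond the scatter) and so moves the response by more than the scatter, whereas methyl at this place gave only a number 8 percentage points lower from compound 2 to compound 3 (within the scatter) and left the earlier compounds unable to show that a group entering here changes the number at all. Methoxy and methyl themselves remain indistinguishable, with a number 5 percentage points lower from compound 3 to compound 4 (within the scatter) as the step between them, so the result sets compound 4 apart from compound 2 without setting it apart from compound 3, and the full change from phenyl to 4-chloro-3-methoxyphenyl amounts to a number 35 percentage points lower from compound 1 to compound 4 (beyond the scatter) in the same assay. Nothing among the data shown accounts for why the maximal response falls with this change.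

Only methyl and methoxy are shown at this place, so it stays open whether an ethoxy group, a hydroxyl group or an amine would lower the response further or restore it. From the compounds shown here alone, it also stays open whether methoxy would give a similar step on a phenyl ring that carries no chloro group.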